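The source may report more compounds than this note shows. Statements on the series, on what has been measured and on what is new or still open speak of the compounds shown alone.

Measured in an ADME assay on HEK293 cells (Homo sapiens) for cytotoxicity, read by reporter gene assay and resazurin assay, with a stated time of 48 h (on this read-out lower numbers stand for higher toxicity in this test and higher numbers for lower toxicity in this test), so far
compound 1 `O=C(Nc1cccc(Cl)c1)c1ccccc1O` gives 37000 nM
compound 2 `COc1ccccc1C(=O)Nc1cccc(Cl)c1` gives > 100000 nM

Compound 2 has no number, only (the limit of > 100000 nM in this assay, at which 1 of the 2 values shown sits). Compound 3 `COc1c(Br)cccc1C(=O)Nc1cccc(Cl)c1` differs from compound 2 by one change, (bromo in place of hydrogen on an aromatic carbon), bromo in place of hydrogen on an aromatic carbon. For the measured compounds named here, the only measured step, an at least 2.7-fold higher number from compound 1 to compound 2 (0.43 log units; beyond the scatter), is a different change, methyl in place of hydrogen on an oxygen on an aromatic ring, so it bears on this one only loosely. Going by the values given here, no measured step brings in bromo, so no step beyond the scatter is expected in this assay. The estimated step is an at least 1.2-fold lower number from compound 2 to compound 3 (0.09 log units; that floor lies within the scatter). For compound 3 the estimate is 80000 nM, with an expected range from 25000 nM to 160000 nM.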

Compound 3, half-maximal cytotoxic concentration: > 100000 nM
Compound 3 was reported as a limit; the forecaster's own chance of this, stated with the estimate: 55%; middle value at least 1.2-fold (0.09 log units) away from the limit.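

No step can be read from compound 2 to compound 3 in this assay, since both compounds are reported only as a limit: the limit of > 100000 nM in this assay, at which 2 of the 3 values shown sit. From the compounds shown here alone, whether bromo in place of hydrogen on an aromatic carbon changes the half-maximal cytotoxic concentration at all stays open.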